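Swapping a Benzyl Chain End for a Dichlorophenoxy Group

The source may report more compounds than this note shows. Statements on the series, on what has been measured and on what is new or still open speak of the compounds shown alone.

In an in vitro functional assay on HEK ts201 cells for antagonist activity at Neuronal acetylcholine receptor; alpha4/beta2 (Homo sapiens), read by fluorescence and calcium flux (a lower number here means a stronger inhibitor, a higher number a weaker inhibitor), compound 3 `CC1CC(=O)N(c2ccccc2C(=O)OCC2CCCN(CCCCCCc3ccccc3)C2)C1=O` gives 29500 nM. Compound 1 `CC1CC(=O)N(c2ccccc2C(=O)OCC2CCCN(CCCCCc3ccccc3)C2)C1=O` gives 24500 nM in this assay, and the shift a 1.2-fold higher number from compound 1 to compound 3 (0.08 log units; within the scatter) leaves the two within the scatter of each other. Compound 2 `COc1cccc(OCCCCCN2CCCC(COC(=O)c3ccccc3N3C(=O)CC(C)C3=O)C2)c1OC` gives 8710 nM in this assay, and the shift a 3.4-fold higher number from compound 2 to compound 3 (0.53 log units; beyond the scatter) sets compound 3 beyond the scatter from compound 2. Compound 4 `CC1CC(=O)N(c2ccccc2C(=O)OCC2CCCN(CCCCCOc3ccc(Cl)c(Cl)c3)C2)C1=O` differs from compound 3 by 3,4-dichlorophenoxy in place of benzyl on a saturated chain carbon, five bonds along the chain from an amine nitrogen in a ring. Of the measured steps only a 3.4-fold higher number from compound 2 to compound 3 (0.53 log units; beyond the scatter) bears on an exchange of benzyl for a phenoxy group, and it reads as a modest change; the reverse direction is therefore expected here, a lower number beyond the scatter. Compound 4 is expected to give 9500 nM in this assay, between 3500 nM and 28000 nM. The estimated step is a 3.1-fold lower number from compound 3 to compound 4 (0.49 log units; beyond the scatter).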

Compound 4, half-maximal inhibitory concentration: 17400 nM
The estimate for compound 4 lay 1.8-fold (0.26 log units) below the measured number, within the range that was stated.
By their numbers in this assay, from the lowest: compounds 2, 4, 1 and 3 (each within the scatter of the next, the first and the last beyond it).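

Unlike the 2,3-dimethoxyphenoxy end of compound 2, the 3,4-dichlorophenoxy end does not stand clear of the all-carbon chain ends (a 1.7-fold lower number from compound 3 to compound 4 (0.23 log units; within the scatter); a 1.4-fold lower number from compound 1 to compound 4 (0.15 log units; within the scatter)). It also lies within the scatter of the dimethoxy group (a 2.0-fold higher number from compound 2 to compound 4 (0.30 log units; within the scatter)), so the two phenoxy ends cannot be told apart, and an oxygen-linked ring at this place does not by itself guarantee a step beyond the scatter. No available evidence explains these results.

Still open, on these data alone, is what plain phenoxy, without chlorine or methoxy groups, would give at this place. So is the effect of an amine or a carboxylic acid at the chain end.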